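Series notes: aryl swap on the amine nitrogen

The source may hold more compounds than are shown below. What is called first, only, known or untested is meant among the compounds shown, and "the series" means these compounds.

Compound 1 `CCOC(=O)C1=C(Nc2ccccc2)S/C(=C\c2cc(OC)ccc2OC)C1=O`: in a functional assay on A549 cells (Homo sapiens) for inhibition, read by MTT assay, with a stated time of 72 h, tested at 10 uM (on this read-out higher numbers stand for more inhibition at the one concentration tested (going by the name of the read-out) and lower numbers for less inhibition), compound 1 gives < 10%, a limit of the assay.
Compound 2 `CCOC(=O)C1=C(Nc2ccc(OC)cc2)S/C(=C\c2ccc[nH]2)C1=O`: in this assay compound 2 gives < 10%, likewise a limit.
Compound 3 `CCOC(=O)C1=C(Nc2ccc(Br)cc2)S/C(=C\c2ccc[nH]2)C1=O`: in this assay compound 3 gives < 10%, again a limit.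

Compound 3 therefore stands only at a limit, as do the other two values shown; (the limit of < 10% in this assay, at which 3 of the 3 values shown sit). Within the data shown here, the one single-point step measured, a step that the two limits leave unreadable from compound 2 to compound 3, cannot be read, since both ends are limits. Compound 4 `CCOC(=O)C1=C(Nc2cccc(F)c2)S/C(=C\c2ccc[nH]2)C1=O` differs from compound 3 by 3-fluorophenyl in place of 4-bromophenyl on an amine nitrogen. Among the measured compounds shown here, no measured step bears readably on this change, so the expectation rests on the shared limit alone. Compound 4 is expected to stay at that limit, with an estimated step that the limit leaves unreadable from compound 3 to compound 4 amounting to nothing beyond the scatter. The estimate for compound 4 is 5%, ranging from 0% to 15%.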

Compound 4, a percentage reported as inhibition, at one concentration (the size of the read-out at that concentration, not a potency): < 10%
Compound 4 gave a limit, no number; the forecaster's own chance of this, stated with the estimate: 80%; the middle value is on the limit's open side.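

Compound 2, compound 3 and compound 4 all sit at a limit, so no step among them can be read: the limit of < 10% in this assay, at which 4 of the 4 values shown sit.

The compounds shown leave open whether any aryl swap on the amine nitrogen changes inhibition in this assay.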